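The source may report more compounds than this note shows. Statements on the series, on what has been measured and on what is new or still open speak of the compounds shown alone.

Compound 1 `Cc1cccc(Cn2cc(COc3ccc4c(=O)ccoc4c3)nn2)c1`, compound 2 `N#Cc1ccc(Cn2cc(COc3ccc4c(=O)ccoc4c3)nn2)cc1` and compound 3 `O=c1ccoc2cc(OCc3cn(Cc4cccc(F)c4)nn3)ccc12` share one core and differ only in the group carried on a saturated chain carbon bound to an aromatic nitrogen. In an ADME assay on L02 cells (Homo sapiens) for cytotoxicity, read by MTT assay, with a stated time of 48 h (a higher number here means a weaker inhibitor, a lower number a stronger inhibitor), compound 1 gives a limit of > 300000 nM. In this assay compound 2 also gives a limit, > 300000 nM. Compound 3 likewise gives a limit of > 300000 nM. Compound 2 therefore stands where every measured compound stands, at the limit of > 300000 nM in this assay, at which 3 of the 3 values shown sit. The steps a step that the two limits leave unreadable from compound 1 to compound 2, a step that the two limits leave unreadable from compound 1 to compound 3 and a step that the two limits leave unreadable from compound 2 to compound 3 are all unreadable; both ends of each sit at a limit, and none yields a size or a direction.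

The compound not yet measured, compound 4 `O=c1ccoc2cc(OCc3cn(Cc4ccccc4Cl)nn3)ccc12`, follows from compound 2 by the change (2-chlorophenyl in place of 4-cyanophenyl on a saturated chain carbon bound to an aromatic nitrogen). The three unreadable steps are the only ones that bear on this change, and they give no basis for expecting movement of any size. The step expected here, a number no higher from compound 2 to compound 4 (the limit leaves the size open), is none beyond the scatter in this assay. With all three measured compounds resting at the limit of > 300000 nM in this assay, at which 3 of the 3 values shown sit, compound 4 is estimated at 300000 nM in this assay, with a range from 100000 nM to 1000000 nM, and it is expected that the result will again be reported only as a limit.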

Compound 4, half-maximal inhibitory concentration: > 300000 nM
Compound 4 ended at the assay's limit; the forecaster's own chance of this, stated with the estimate: 85%; the middle value lies on the limit itself.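

In this assay, among the compounds shown here, compound 4 gives > 300000 nM, a limit and not a number, so no step linking it to compound 1, compound 2 or compound 3 can be read. The four compounds share one position: the limit of > 300000 nM in this assay, at which 4 of the 4 values shown sit. The compounds shown leave open how these four rank against one another in this assay, and whether any group at this place on the shared core would give a readable value.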